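The source may report more compounds than this note shows. Statements on the series, on what has been measured and on what is new or still open speak of the compounds shown alone.

Measured compounds:
Compound 1, `COc1ccc(C2SCC(=O)N2CCN2CCCCC2)cc1`, gives 100% in an ADME assay on Vero cells (Chlorocebus sabaeus) for cytotoxicity, read by neutral red uptake, tested at 25 ug/mL; a lower number here means a stronger effect, a higher number a weaker effect of the compound at the concentration tested.
Compound 2, `O=C1CSC(c2cccc(Cl)c2)N1CCN1CCCCC1`, gives 100% in this assay.
Compound 3, `O=C1CSC(c2ccccc2Cl)N1CCN1CCCCC1`, gives 100% in this assay.

Compound 3 stands level with compound 1 and compound 2 at the digits printed in this assay; its nearest neighbour is compound 1 and its furthest is compound 2, and neither gap goes beyond the scatter. The one measured step among these compounds, no change at the digits printed from compound 2 to compound 3 (within the scatter), is a no-change step. Compound 4, `O=C1CSC(c2ccc(Cl)cc2)N1CCN1CCCCC1`, has not yet been measured. It differs from compound 3 as follows: 4-chlorophenyl in place of 2-chlorophenyl on a saturated ring carbon. The measured step that bears on this change is the step from compound 2 to compound 3, which moved the chlorine on the phenyl ring and gave no change. For the measured compounds named here, since every compound so far reads at the same level in this assay, no step beyond the scatter is expected for compound 4. Compound 4 is therefore estimated at 100%, with a range from 90% to 100%, which amounts to an expected step of no change at the digits printed from compound 3 to compound 4 (within the scatter).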

Compound 4, a percentage reported as activity, at one concentration (the size of the read-out at that concentration, not a potency): 84%
Compound 4: middle estimate off by 16 percentage points, on the high side, and the stated range ends above it.
By their numbers in this assay, from the lowest: compound 4; then compounds 1, 2 and 3 (each within the scatter of the next).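

In this assay the arrangement of the chlorophenyl group on the saturated ring carbon now matters: 4-chlorophenyl in place of 2-chlorophenyl gives a number 16 percentage points lower from compound 3 to compound 4 (beyond the scatter) and 4-chlorophenyl in place of 3-chlorophenyl gives a number 16 percentage points lower from compound 2 to compound 4 (beyond the scatter) even though the step between the other two chlorophenyl compounds stays within the scatter. Chloro in place of methoxy on an aromatic carbon gives a number 16 percentage points lower from compound 1 to compound 4 (beyond the scatter) as well, so compound 4 alone leaves the level shared by compounds 1, 2 and 3, and the effect is tied to neither the chlorine alone nor the aromatic carbon alone. Nothing at hand explains why this one compound departs from the others.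

On these data alone, whether a bromo, fluoro or methyl group on that aromatic carbon would give a similar step stays open. So does whether an amine or a carboxylic acid there would read with compound 4 or with compound 1.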